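The compounds below may be only part of what the source reports. "The series", "measured", "known", "first", "only" and "open" are said of these compounds alone.

Of the compounds shown here, three sharing one core have been measured so far. Compound 1 `CC(C)CCc1ccc2c(NCCCNCc3ccco3)ccnc2c1` gives 4200 nM in a physicochemical assay for solubility, with a stated time of 18 h, at pH 7.4; on this read-out lower numbers stand for lower solubility and higher numbers for higher solubility. Compound 2 `CCC(CC)c1ccc2c(NCCCNCc3ccco3)ccnc2c1` gives 4200 nM in this assay, and the step of no change at the digits printed from compound 1 to compound 2 (within the scatter) shows that these two values sit within the scatter of each other. Compound 3 `COc1ccc(-c2ccc3c(NCCCNCc4ccco4)ccnc3c2)cc1`, which carries a 4-methoxyphenyl group where the other two carry a branched alkyl chain, gives 32000 nM in this assay and stands highest of the three numbers; the steps of a 7.6-fold higher number from compound 1 to compound 3 (0.88 log units; beyond the scatter) and a 7.6-fold higher number from compound 2 to compound 3 (0.88 log units; beyond the scatter) were both beyond the scatter, though only modest in size.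

Compound 4 `c1coc(CNCCCNc2ccnc3cc(-c4cccc5ccccc45)ccc23)c1` has not yet been measured. It differs from compound 3 in one place: naphthalen-1-yl in place of 4-methoxyphenyl on an aromatic carbon. Among the compounds with values here, no measured step swaps one aromatic group for another, so the two steps from an alkyl chain to 4-methoxyphenyl are the only guide, and they bear on the change only loosely. Because compound 3 rose over compound 1 by a 7.6-fold higher number from compound 1 to compound 3 (0.88 log units; beyond the scatter), and compound 4 loses the single hydrogen-bond acceptor that entered in that step while adding a second aromatic ring of carbon only, a modest fall is expected, namely a 4.0-fold lower number from compound 3 to compound 4 (0.60 log units; beyond the scatter). Compound 4 is therefore estimated at 8000 nM, with a range from 2000 nM to 30000 nM.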

Compound 4, solubility: 32000 nM
Estimate against measurement, compound 4: 4.0-fold (0.60 log units) below; measured number outside the range, above it.
By their numbers in this assay, from the lowest: compounds 1 and 2 (each within the scatter of the next); then compounds 3 and 4 (each within the scatter of the next).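

In this assay, naphthalen-1-yl and 4-methoxyphenyl on this aromatic carbon sit within the scatter of each other (no change at the digits printed from compound 3 to compound 4 (within the scatter)), even though one group holds a hydrogen-bond acceptor and a single aromatic ring while the other is carbon only, with two aromatic rings. Within the data shown here, the alkyl compounds read lower than this new aromatic compound (a 7.6-fold higher number from compound 2 to compound 4 (0.88 log units; beyond the scatter); a 7.6-fold higher number from compound 1 to compound 4 (0.88 log units; beyond the scatter)), so the step from a branched alkyl chain to an aromatic group, until now seen only with 4-methoxyphenyl, also appears with a group that has no oxygen, and none of these four compounds goes against that pattern. Nothing measured here explains why the numbers fall this way.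

As far as these compounds go, it remains open whether a plain phenyl, or an aromatic ring carrying a carboxylic acid or an amine, would group with compounds 3 and 4 at this position. From the compounds shown here alone, it is also open whether a methyl group or a longer alkyl chain would group with compounds 1 and 2, and whether the same pattern would hold with a change elsewhere on the shared core.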